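The source may hold more compounds than are shown below. What is called first, only, known or untested is meant among the compounds shown, and "the series" means these compounds.

Values measured in a functional assay on U-937 cells (Homo sapiens); on this read-out higher numbers stand for weaker inhibition and lower numbers for stronger inhibition:

- compound 1 `COc1cc(C(=O)NS(=O)(=O)c2ccccc2C)ccc1Cc1cn(C(F)F)c2ccc(NC(=O)OC3CCCC3)cc12`: 0.4 nM
- compound 2 `COc1cc(C(=O)NS(=O)(=O)c2ccccc2C)ccc1Cc1c[nH]c2ccc(NC(=O)OC3CCCC3)cc12`: 2 nM

Of the two, compound 2 stands higher at 2 nM, which makes it the weaker inhibitor in this assay, and the gap lies beyond the scatter. Compound 3 `COc1cc(C(=O)NS(=O)(=O)c2ccccc2C)ccc1Cc1cn(C(=O)N(C)C)c2ccc(NC(=O)OC3CCCC3)cc12` keeps the core of compound 2 and differs in one place: dimethylcarbamoyl in place of hydrogen on an aromatic nitrogen, in words dimethylcarbamoyl in place of hydrogen on an aromatic nitrogen.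

Going by the values given here, only one measured step bears on this change, and it involves an aromatic nitrogen too: a 5.0-fold higher number from compound 1 to compound 2 (0.70 log units; beyond the scatter). This modest step shows hydrogen with the higher number and difluoromethyl with the lower. Among the compounds with values here, no dimethylcarbamoyl compound has been measured, so this single step is only a loose guide. A modest move towards a lower number is therefore expected, and the estimated step is a 2.2-fold lower number from compound 2 to compound 3 (0.35 log units; beyond the scatter). The expected value for compound 3 is 0.9 nM, with an estimated range of 0.25 nM to 4 nM.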

Compound 3, half-maximal inhibitory concentration: 1 nM
Compound 3: middle estimate off by 1.1-fold (0.05 log units), on the low side; measured number inside the range.
By their numbers in this assay, from the lowest: compound 1; then compounds 3 and 2 (each within the scatter of the next).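

In this assay the aromatic nitrogen carries dimethylcarbamoyl, a group of 5 heavy atoms, and the result is a 2.0-fold lower number from compound 2 to compound 3 (0.30 log units; within the scatter) and so compound 3 cannot be separated from compound 2. The same group falls short of difluoromethyl on this nitrogen, with a 2.5-fold higher number from compound 1 to compound 3 (0.40 log units; beyond the scatter) and this shows that the choice of group here can shift the number beyond the scatter. So far, difluoromethyl is the only group at this position that separates from hydrogen beyond the scatter, while a much larger group with a carbonyl still keeps the number close to that of hydrogen.

On these data alone, it remains open how a methyl, an aminoethyl or a carboxylic acid chain on this nitrogen would compare with these groups. As far as these compounds go, it is also open whether the same order would hold with a different group in place of the cyclopentyl carbamate. Nothing available here explains these differences.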